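From fluoro to methoxy at the assay limit

The source may report more compounds than this note shows. Statements on the series, on what has been measured and on what is new or still open speak of the compounds shown alone.

In an ADME assay on Huh-7 cells (Homo sapiens) for cytotoxicity, read by a luciferase reporter and WST assay, with a stated time of 3 days (on this read-out lower numbers stand for higher toxicity in this test and higher numbers for lower toxicity in this test), compound 3 `O=C(NCCO)c1c(NO)cc(-c2ccc(F)cc2)oc1=O` gives > 20000 nM as a limit of the assay and not a number. Compound 2 `O=C(NCCO)c1c(NO)cc(-c2ccccc2)oc1=O` gives > 20000 nM as a limit too. Compound 3 therefore stands at the limit of > 20000 nM in this assay, at which 2 of the 3 values shown sit, and has no exact number to start from.

The next compound, compound 4 `COc1ccc(-c2cc(NO)c(C(=O)NCCO)c(=O)o2)cc1`, differs from compound 3 by methoxy in place of fluoro on an aromatic carbon and so carries methoxy in place of fluoro on an aromatic carbon. Among the compounds with values here, the one measured step at that place is a step that the two limits leave unreadable from compound 2 to compound 3 and it offers no size to carry over. Methoxy also stands on compound 1 `COc1ccc(-c2cc(NO)c(C(=O)Nc3ccccc3)c(=O)o2)cc1`, which has a different group on the amide. Within the data shown here, compound 1 gives 16200 nM, the only number for a methoxy compound. On that ground compound 4 is expected to remain near the limit, with no step beyond the scatter expected in either direction and a limit again the likeliest report. In size the expected step is a step that the limit leaves unreadable from compound 3 to compound 4 and the data support nothing sharper. For compound 4 the estimate is 22000 nM in the middle of an expected range from 12000 nM to 40000 nM on this read-out.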

Compound 4, half-maximal cytotoxic concentration: > 20000 nM
Compound 4 gave a limit, no number (the forecaster's own chance of this, stated with the estimate: 70%); the middle value does not contradict the limit.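

In this assay, the 2-hydroxyethyl amide series now carries hydrogen, fluoro or methoxy on the aromatic carbon para to a large group, and all three compounds end at a limit of the assay: the limit of > 20000 nM in this assay, at which 3 of the 4 values shown sit. The steps among compound 2, compound 3 and compound 4 cannot be read, so the change from fluoro to methoxy has no measurable size here. What is new is a pair that shares methoxy and differs only on the amide nitrogen, with 2-hydroxyethyl in place of phenyl; it gives an at least 1.2-fold higher number from compound 1 to compound 4 (0.09 log units; that floor lies within the scatter), so this pair establishes no step beyond the scatter, although the true step could be larger.

The compounds shown leave open how an amine, a carboxylic acid or a longer chain on the amide nitrogen would read in this assay. Also open, as far as these compounds go, is whether hydrogen or fluoro in place of methoxy on the phenyl amide, where compound 1 gives 16200 nM, would yield a step that can be read.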